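The source may hold more compounds than are shown below. What is called first, only, known or untested is meant among the compounds shown, and "the series" means these compounds.

Compound 2 `COCC(=O)Nc1c(C(O)(C(F)(F)F)C(F)(F)F)ccc2ccccc12` gives 213 nM in an assay on LtK cells with ATP-sensitive inward rectifier potassium channel 11 (Homo sapiens) as the target (on this read-out higher numbers stand for an effect only at larger amounts of compound and lower numbers for an effect already at smaller amounts), the second highest of the three numbers in hand. Compound 1 `CC(C)=CC(=O)Nc1c(C(O)(C(F)(F)F)C(F)(F)F)ccc2ccccc12` gives 46 nM, and compound 3 `O=C(Nc1ccc(Cl)cc1)Nc1c(C(O)(C(F)(F)F)C(F)(F)F)ccc2ccccc12` gives 276 nM. Compound 4 `O=C(Nc1c(C(O)(C(F)(F)F)C(F)(F)F)ccc2ccccc12)c1cccc([N+](=O)[O-])c1` is still unmeasured; it differs from compound 2 by 3-nitrophenyl in place of methoxymethyl on a carbonyl carbon. Within the data shown here, the steps that bear on this are a 4.6-fold higher number from compound 1 to compound 2 (0.67 log units; beyond the scatter) and a 6.0-fold higher number from compound 1 to compound 3 (0.78 log units; beyond the scatter), both modest, whereas a 1.3-fold higher number from compound 2 to compound 3 (0.11 log units; within the scatter) stays within the scatter. Compound 3 also carries an aromatic ring at that carbonyl, joined through an amino group, and its number sits close to compound 2. On that basis the expected step is a 1.3-fold lower number from compound 2 to compound 4 (0.12 log units; within the scatter), in either direction or none beyond the scatter. Compound 4 is therefore estimated at 160 nM in this assay, within a range from 50 nM to 500 nM.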

Compound 4, half-maximal effective concentration: 117 nM
For compound 4 the middle estimate is 1.4-fold (0.14 log units) above the measured one; the measured number falls inside the stated range.
By their numbers in this assay, from the lowest: compound 1; then compounds 4, 2 and 3 (each within the scatter of the next, the first and the last beyond it).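

In this assay, 3-nitrophenyl in place of methoxymethyl gives a 1.8-fold lower number from compound 2 to compound 4 (0.26 log units; within the scatter) and so shows that an aromatic ring joined directly to the carbonyl carbon is accepted here. Aromatic groups at this place do not all read alike, as (4-chlorophenyl)amino giving way to 3-nitrophenyl brings a 2.4-fold lower number from compound 3 to compound 4 (0.37 log units; beyond the scatter) and 2-methylprop-1-en-1-yl still holds the lowest number, with a 2.5-fold higher number from compound 1 to compound 4 (0.41 log units; beyond the scatter) in the step to the nitro compound. Nothing measured here explains these steps. From the compounds shown here alone, whether the ring alone or its nitro group matters stays open. Plain phenyl or 3-aminophenyl at this carbonyl carbon would separate the two.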